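Replacing ethoxycarbonyl with methyl in compound 2

A few compounds are considered here, and "the series" means these few. Any claim that something is new, unique, unknown or untested is made for them only; others in the source may bear on it.

Measured so far in a functional assay on RPMI-8226 cells (Homo sapiens) for cytotoxicity, read by fluorescence, with a stated time of 72 h (on this read-out lower numbers stand for stronger inhibition and higher numbers for weaker inhibition), are three compounds:
- Compound 1 `Nc1n[nH]c(N)c1/N=N/c1ccncc1` gives 6200 nM as its value
- Compound 2 `CCOC(=O)n1nc(N)c(/N=N/c2ccc(O)cc2)c1N` gives > 100000 nM as a limit
- Compound 3 `Cn1nc(N)c(/N=N/c2ccncc2)c1N` gives 50000 nM as its value

The value of compound 2 is a limit of the assay and not a number. For the measured compounds named here, that places compound 2 at the limit of > 100000 nM in this assay, at which 1 of the 3 values shown sits, and leaves no measured step starting from it.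

Compound 4 `Cn1nc(N)c(/N=N/c2ccc(O)cc2)c1N` has not yet been measured. It carries methyl in place of ethoxycarbonyl on an aromatic nitrogen and is otherwise the same as compound 2.

Going by the values given here, no measured step makes this exact change. The nearest one is methyl in place of hydrogen on an aromatic nitrogen, which gives an 8.1-fold higher number from compound 1 to compound 3 (0.91 log units; beyond the scatter) and bears only indirectly on the question. Compound 3 has the methyl of compound 4 but differs from it elsewhere. The value of compound 3, 50000 nM, is the main anchor for the expectation. That expectation is a modest move to a lower number that may not clear the limit.

The step expected is an at least 2.2-fold lower number from compound 2 to compound 4 (0.34 log units; beyond the scatter) and it is only an estimate, set against a limit. For compound 4 the expected value in this assay is 45000 nM with an estimated range from 12000 nM to 100000 nM at its upper end.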

Compound 4, half-maximal inhibitory concentration: > 100000 nM
Compound 4: no number, only a limit (the forecaster's own chance of this, stated with the estimate: 40%); at least 2.2-fold (0.34 log units) between middle value and limit.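

In this assay compound 4 gives > 100000 nM, a limit of the assay and not a number. Compound 2 also stands at a limit, and the step from compound 2 to compound 4 cannot be read. The compounds shown leave open whether methyl in place of ethoxycarbonyl on an aromatic nitrogen changes the value at all.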